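A few compounds are considered here, and "the series" means these few. Any claim that something is new, unique, unknown or untested is made for them only; others in the source may bear on it.

Compound 3 `O=C(O)[C@@H]1NC[C@@H](O)[C@@H](O)[C@@H]1O` sits at the bottom of the three numbers in an assay for inhibition of alpha-N-acetylgalactosaminidase (Gallus gallus), tested at 1000 uM; on this read-out higher numbers stand for more inhibition at the one concentration tested (going by the name of the read-out) and lower numbers for less inhibition: compound 3 gives 7.2%, compound 2 `O=C(O)[C@@H]1NC[C@@H](O)[C@H](O)[C@@H]1O` gives 10%, and compound 1 `O=C(O)[C@H]1NC[C@H](O)[C@@H](O)[C@H]1O` gives 31%. Compound 4 `O=C(O)[C@@H]1NC[C@H](O)[C@@H](O)[C@H]1O` has not yet been measured; its change from compound 3 is the two compounds have the same atoms and bonds and differ only in configuration as drawn: 2 of 4 stereo elements differ; a stereocentre at a saturated ring carbon is drawn R in compound 3 and S in compound 4; a stereocentre at a saturated ring carbon is drawn R in compound 3 and S in compound 4. The measured steps are all changes of configuration: a number 2.8 percentage points lower from compound 2 to compound 3 (within the scatter), a number 23.8 percentage points lower from compound 1 to compound 3 (beyond the scatter) and a number 21 percentage points lower from compound 1 to compound 2 (beyond the scatter). So flipping stereocentres has moved this read-out anywhere from nothing to a modest amount, in either direction. A moderate change is therefore expected for compound 4, most likely upward, with a number 7.8 percentage points higher from compound 3 to compound 4 (within the scatter) as the estimated step. Compound 4 is estimated at 15%, in the range 4% to 32%.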

Compound 4, a percentage reported as inhibition, at one concentration (the size of the read-out at that concentration, not a potency): 4%
Beside the measured number, compound 4's estimate is 11 percentage points above it; the range from low to high includes it.
By their numbers in this assay, from the lowest: compounds 4, 3 and 2 (each within the scatter of the next); then compound 1.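

Compound 1 and compound 4 differ at a single stereocentre at a saturated ring carbon, and that one inversion is enough to lose most of the inhibition: a number 27 percentage points lower from compound 1 to compound 4 (beyond the scatter) in this assay. Larger changes of configuration need not register, as a number 3.2 percentage points lower from compound 3 to compound 4 (within the scatter) and a number 6 percentage points lower from compound 2 to compound 4 (within the scatter) show, so compounds 2, 3 and 4 form one low group and only compound 1 stands apart.

Why this one stereocentre counts remains open. So does whether an amide or a hydroxymethyl group in place of the carboxylic acid would keep the inhibition of compound 1.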